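Cytotoxicity notes on the series, compound 2 to compound 4

The compounds below may be only part of what the source reports. "The series", "measured", "known", "first", "only" and "open" are said of these compounds alone.

Three compounds of the series have been run in an ADME assay on MT2 cells (Homo sapiens) for cytotoxicity, read by XTT assay, with a stated time of 4 days; a lower number here means that less compound is tolerated, a higher number that more compound is tolerated. Compound 1 `Cc1ccc(-c2c(C(OC(C)(C)C)C(=O)O)c(C)nc3ccccc23)cc1` gives a limit of the assay, > 40000 nM, and not a number. Compound 3 `Cc1ccc(-c2c3c(nc(C)c2C(OC(C)(C)C)C(=O)O)CCN(C)C3)cc1` likewise gives only a limit, > 40000 nM. Compound 2 `Cc1nc2c(c(-c3cc(F)c4c(c3C)CCCO4)c1[C@H](OC(C)(C)C)C(=O)O)CN(CCCc1ccccc1F)CC2` also sits at a limit in this assay, > 40000 nM. Compound 2 therefore stands where every measured value of the series stands, at the limit rather than at a number, and no order among the three can be drawn. Within the data shown here, the only evidence is the limit of > 40000 nM in this assay, at which 3 of the 3 values shown sit.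

Compound 4 `Cc1cccc(CCCN2CCc3nc(C)c([C@H](OC(C)(C)C)C(=O)O)c(-c4cc(F)c5c(c4C)CCCO5)c3C2)c1` is not yet measured. It differs from compound 2 in one place: 3-methylphenyl in place of 2-fluorophenyl on a saturated chain carbon, three bonds along the chain from an amine nitrogen in a ring. Among the measured compounds shown here, no step between two measured compounds is known for this change, or for any other change. Because all three values sit at the limit of > 40000 nM in this assay, at which 3 of the 3 values shown sit, the step is expected to be none beyond the scatter, with compound 4 most likely returning another limit. The expected step is a number no higher from compound 2 to compound 4 (the limit leaves the size open). Compound 4 is estimated at 40000 nM in this assay, with a range from 20000 nM to 80000 nM.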

Compound 4, half-maximal cytotoxic concentration: > 40000 nM
Compound 4: only a limit was reported; the forecaster's own chance of this, stated with the estimate: 85%; the middle value lies on the limit itself.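

No step can be read from compound 2 to compound 4 in this assay, as both results are limits: the limit of > 40000 nM in this assay, at which 4 of the 4 values shown sit.

The compounds shown leave open where any true half-maximal cytotoxic concentration lies, and whether 3-methylphenyl and 2-fluorophenyl differ at all in this assay.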